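The source may report more compounds than this note shows. Statements on the series, on what has been measured and on what is new or still open speak of the compounds shown alone.

In a physicochemical assay for solubility, in phosphate buffer, at pH 7.4 (a higher number here means a more soluble compound, a lower number a less soluble compound), compound 2 `CCOC(=O)c1c(-c2ccccc2Cl)[nH]c2cccc(OC)c2c1=O` stands at > 100000 nM, which is a limit and not a number. Compound 1 `CCOC(=O)c1c(-c2ccccc2)[nH]c2cc(OC)ccc2c1=O` gives > 100000 nM, also a limit. The series therefore sits largely at the limit of > 100000 nM in this assay, at which 2 of the 3 values shown sit. Only compound 3 `CCOC(=O)c1c(-c2ccc(OC)cc2)[nH]c2cc(OC)ccc2c1=O` gives a number, 8000 nM.

The change under review leads to compound 4 `CCOC(=O)c1c(-c2cccc([N+](=O)[O-])c2)[nH]c2cccc(OC)c2c1=O`: 3-nitrophenyl in place of 2-chlorophenyl on an aromatic carbon. In words, 3-nitrophenyl stands in place of 2-chlorophenyl on an aromatic carbon, next to the ring nitrogen. Going by the values given here, no measured step exchanges these two groups. Among the compounds with values here, the one measured step is an at least 12-fold lower number from compound 1 to compound 3 (1.09 log units; beyond the scatter), and it bears on this change only loosely, as a different substitution on a different starting compound. Its size is also only a minimum. Since compound 2 has no number, the size of any change from it cannot be fixed precisely.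

A lower number is expected for the new compound because an at least 12-fold lower number from compound 1 to compound 3 (1.09 log units; beyond the scatter) came with a single added methoxy. The step is expected to be an at least 4.0-fold lower number from compound 2 to compound 4 (0.60 log units; beyond the scatter). This expectation is very uncertain. Compound 4 is estimated at 25000 nM, with an expected range of 4000 nM to 100000 nM.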

Compound 4, solubility: 49000 nM
Compound 4: the middle estimate sits 2.0-fold (0.29 log units) below what was measured; the range from low to high includes it.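

In this assay, exchanging the group on the aromatic carbon next to the ring nitrogen, 3-nitrophenyl in place of 2-chlorophenyl, gives an at least 2.0-fold lower number from compound 2 to compound 4 (0.30 log units; that floor lies within the scatter). Compound 2 gives > 100000 nM, which is a limit and not a number, so the step can be read only as a floor, and that floor does not establish a real difference: the limit of > 100000 nM in this assay, at which 2 of the 4 values shown sit. Going by these compounds alone, compound 4 gives 49000 nM, so this exchange provides the first read-out with a number for a change of this group on the core of compound 2, whereas the only earlier number, for compound 3, belongs to the core of compound 1.

The compounds shown do not separate the loss of 2-chlorophenyl from the arrival of 3-nitrophenyl, and they leave open whether the true size of the step lies beyond the scatter. Also open, on these data alone, is how a group of another kind on this phenyl ring, such as an amine or a carboxylic acid, would read in this assay on the core of compound 2.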